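From bromo to iodo: compound 1 and compound 3

The source may hold more compounds than are shown below. What is called first, only, known or untested is meant among the compounds shown, and "the series" means these compounds.

- compound 1 `Cc1cn([C@@H]2O[C@H](CO[Si](C)(C)C(C)(C)C)[C@@]3(OS(=O)(=O)C(Br)=C3N)[C@H]2O[Si](C)(C)C(C)(C)C)c(=O)[nH]c1=O`: 18000 nM
- compound 2 `CC1=C(N)[C@@]2(OS1(=O)=O)[C@@H](CO[Si](C)(C)C(C)(C)C)O[C@@H](n1cc(C)c(=O)n(C)c1=O)[C@@H]2O[Si](C)(C)C(C)(C)C`: > 250000 nM

Of the compounds shown here, two have been measured in a functional assay on MT4 cells (Homo sapiens) for cytotoxicity; on this read-out higher numbers stand for lower toxicity in this test and lower numbers for higher toxicity in this test. In this assay, going by the values given here, compound 1 gives 18000 nM, which is the only exact number available. Compound 2 gives > 250000 nM, and this is a limit of the assay rather than a number. Compound 1 therefore stands as the single fixed point on the scale, and it is the natural starting point for what follows.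

Compound 3 `Cc1cn([C@@H]2O[C@H](CO[Si](C)(C)C(C)(C)C)[C@@]3(OS(=O)(=O)C(I)=C3N)[C@H]2O[Si](C)(C)C(C)(C)C)c(=O)[nH]c1=O` keeps the core of compound 1 and changes it in one place: iodo in place of bromo on a double-bonded ring carbon. It carries iodo in place of bromo on a double-bonded ring carbon, next to the ring sulfur and next to the ring atom that bears an amino group. Among the compounds with values here, no measured pair shows what such an exchange does, so the expectation rests on compound 1 at 18000 nM. A small step is expected a 1.2-fold lower number from compound 1 to compound 3 (0.08 log units; within the scatter), and it is not expected to go beyond the usual scatter. For compound 3 the estimated value is 15000 nM, with an expected range from 6000 nM to 40000 nM.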

Compound 3, half-maximal cytotoxic concentration: 4300 nM
The estimate for compound 3 lay 3.5-fold (0.54 log units) above the measured number; the measured number lies below the stated range.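

In this assay, going by these compounds alone, the exchange of bromo for iodo on the double-bonded ring carbon gives the first single-place comparison: a 4.2-fold lower number from compound 1 to compound 3 (0.62 log units; beyond the scatter) and so toward higher toxicity in this test. This shows that the position, next to the ring sulfur and next to the ring atom that bears an amino group, is sensitive to the identity of the halogen, even though the change adds no ring, hydrogen-bond donor, hydrogen-bond acceptor or net charge. Nothing among the data shown explains the size of this step.

Going by these compounds, whether chloro or a nitrile on this same ring carbon would lower the number further, leave it unchanged or raise it remains open, as one pair cannot show a trend across substituents. Also open, on these data alone, is whether the step from bromo to iodo would persist if free hydroxyl groups replaced the silyl ethers on the shared core.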